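Swapping the amide link: compound 1 to compound 3

The source may hold more compounds than are shown below. What is called first, only, known or untested is meant among the compounds shown, and "the series" means these compounds.

compound 1 `C#CCNC(=O)c1cccc2c1cc(C)n2-c1nc2c(c(NCc3ccccc3)n1)COCC2`: 1080 nM
compound 2 `CCCC#CC(=O)Nc1cccc2c1cc(C)n2-c1nc2c(c(NCc3ccccc3)n1)CCCC2`: 1570 nM

Among the compounds with values here, in a functional assay on MIA PaCa-2 cells (Homo sapiens) for antiproliferative activity (a lower number here means that less compound is needed, a higher number that more compound is needed for the effect), compound 1 gives 1080 nM, the lower of only two numbers, though compound 2 at 1570 nM lies within the scatter of it, so no order can be read between them. Compound 3 `CC#CC(=O)Nc1cccc2c1cc(C)n2-c1nc2c(c(NCc3ccccc3)n1)COCC2` keeps the core of compound 1 and carries ((prop-1-yn-1-yl)carbonyl)amino in place of propargylcarbamoyl on an aromatic carbon. Within the data shown here, no measured step isolates this change, so the basis is thin. Compound 2, whose amide is also joined through its nitrogen, gives 1570 nM, and that offers no sign of a large shift. The estimated change, a 1.2-fold higher number from compound 1 to compound 3 (0.08 log units; within the scatter), is expected to stay within the scatter in this assay, with no direction favoured. For compound 3 the expected value is 1300 nM, with an estimated range of 450 nM to 3800 nM.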

Compound 3, half-maximal effective concentration: 600 nM
For compound 3 the middle estimate is 2.2-fold (0.34 log units) above the measured one; measured number inside the range.
By their numbers in this assay, from the lowest: compounds 3, 1 and 2 (each within the scatter of the next, the first and the last beyond it).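

Within the data shown here, with the shared core held, the only step that isolates the link at this position is ((prop-1-yn-1-yl)carbonyl)amino in place of propargylcarbamoyl on an aromatic carbon, which in this assay gives a 1.8-fold lower number from compound 1 to compound 3 (0.26 log units; within the scatter) and so stays inside the scatter. The two groups count the same atoms, so the step concerns how they are joined: an amide attached through its nitrogen or through its carbonyl carbon makes no readable difference at this position in this assay. Nothing available explains this result. From the compounds shown here alone, whether the triple bond itself matters at this position stays open, and a plain acetamide or a saturated butanamide chain on the same aromatic carbon would test it. Also open, going by these compounds, is how this position responds to a primary amine or a carboxylic acid, which would show whether the amide link is needed at all.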